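The source may hold more compounds than are shown below. What is called first, only, known or untested is meant among the compounds shown, and "the series" means these compounds.

Compound 1 `CCCCCCOc1ccc2c(Cl)ccnc2c1` is tested in a functional assay on SK-OV-3 cells (Homo sapiens) for cytotoxicity, read by MTT assay, with a stated time of 48 h (a lower number here means a stronger inhibitor, a higher number a weaker inhibitor), where it gives only a limit, > 10000 nM. Among the compounds with values here, compound 3 `CCCCCCOc1ccc2c(NCCN(C)C)ccnc2c1` gives 1860 nM in this assay, and the step of an at least 5.3-fold lower number from compound 1 to compound 3 (0.73 log units; beyond the scatter) is the one measured change of a single group. Compound 2 `C=CCOc1ccc2c(NCCCN(C)C)ccnc2c1` gives 4250 nM, the highest of the two numbers. Compound 4 `CN(C)CCCNc1ccnc2cc(OCc3ccc(F)cc3)ccc12` has not yet been measured; its change from compound 2 is 4-fluorophenyl in place of vinyl on a saturated chain carbon bound to an oxygen on an aromatic ring. Within the data shown here, the one measured step alters the amine side of the shared core, not the ether chain, so no measured step bears directly on this change. Compound 4 is therefore expected to lie near compound 2, with the estimated step of a 1.7-fold lower number from compound 2 to compound 4 (0.23 log units; within the scatter), giving an estimate of 2500 nM in a range from 800 nM to 8000 nM.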

Compound 4, half-maximal inhibitory concentration: 1280 nM
Compound 4: middle estimate off by 2.0-fold (0.29 log units), on the high side; low and high end bracket the measured number.
By their numbers in this assay, from the lowest: compounds 4 and 3 (each within the scatter of the next); then compound 2. At a limit, above all of these: compound 1.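

Within the data shown here, the earlier measured step changed the amine side of the shared core, and this is the first measured change at the ether group: with allyl replaced by 4-fluorobenzyl, this assay gives a 3.3-fold lower number from compound 2 to compound 4 (0.52 log units; beyond the scatter). The ether position therefore affects the result, even with the amine side left unchanged. In this one pair, the larger group carrying an aromatic ring goes with the lower number.

Whether the ring alone accounts for the step or the fluorine also contributes stays open, and plain benzyl or 4-methoxybenzyl at this position would help to separate the two. Nothing measured here gives a reason for the step.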